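The source may hold more compounds than are shown below. What is called first, only, known or untested is meant among the compounds shown, and "the series" means these compounds.

Three compounds have so far been measured in a functional assay on MCF7 cells (Homo sapiens) for inhibition, read by MTT assay, with a stated time of 72 h; on this read-out higher numbers stand for weaker inhibition and lower numbers for stronger inhibition:

compound 1 `CC(Nc1nnc2nncn2n1)C(=O)O`: > 100000 nM
compound 2 `CCCCC(=O)N1CCN(c2nnc3nncn3n2)CC1`: 2760 nM
compound 3 `CN(C)c1nnc2nncn2n1`: 7760 nM

The value of compound 1 is a limit of the assay and not a number (the limit of > 100000 nM in this assay, at which 1 of the 3 values shown sits). Among the two numbers, compound 2 gives the lower one, and compound 3 sits above it by a gap that lies beyond the usual scatter.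

Compound 4 `CC(C)COC(=O)N1CCN(c2nnc3nncn3n2)CC1` has not yet been measured in this assay . It differs from compound 2 in one place (isobutoxy in place of butyl on a carbonyl carbon). Going by the values given here, no measured pair in this set shows a change of this kind, so there is no comparable step to lean on. The carbonyl attached to the ring nitrogen is kept, and the chain it carries stays at four carbons, so only a modest movement is expected. Compound 4 is estimated at 3500 nM, within 1200 nM to 10000 nM, which amounts to an expected step of a 1.3-fold higher number from compound 2 to compound 4 (0.10 log units; within the scatter) — a shift that is expected to stay within, or only just beyond, the scatter of this assay .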

Compound 4, half-maximal inhibitory concentration: 5390 nM
Compound 4: the middle estimate sits 1.5-fold (0.19 log units) below what was measured; low and high end bracket the measured number.
By their numbers in this assay, from the lowest: compounds 2, 4 and 3 (each within the scatter of the next, the first and the last beyond it). At a limit, above all of these: compound 1.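

In this assay, going by these compounds alone, the first step at this position, the butylcarbonyl to isobutoxycarbonyl change on the amide-type ring nitrogen, gives a 2.0-fold higher number from compound 2 to compound 4 (0.29 log units; within the scatter). So at this carbonyl carbon, isobutoxy, with its added oxygen and hydrogen-bond acceptor, can take the place of butyl without a difference that can be read beyond the scatter. Nothing available here bears on why the two compounds read as they do.

On these data alone, whether the same holds for other groups on this carbonyl carbon, such as an amine, a carboxylic acid or a longer chain, remains open. Within the data shown here, no single-place step links compound 1 or compound 3 to this pair, so what the carbonyl-bearing part contributes to the read-out on the shared core also remains open.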